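A few compounds are considered here, and "the series" means these few. Any claim that something is new, unique, unknown or untested is made for them only; others in the source may bear on it.

Compound 1 `CCN(CC)S(=O)(=O)c1ccc(S(=O)(=O)N2CCC[C@@H](C(=O)N[C@H]3CC[C@H](OC)CC3)C2)cc1` and compound 2 `CCN(CC)S(=O)(=O)c1ccc(S(=O)(=O)N2CCC[C@@H](C(=O)N3CCC(COC)CC3)C2)cc1` share one core and differ only in the group on the carbonyl carbon. In a functional assay on BXPC-3 cells (Homo sapiens) for inhibition, read by MTT assay, with a stated time of 7 days (a higher number here means a weaker inhibitor, a lower number a stronger inhibitor), compound 1 gives 2000 nM, and compound 2 gives 1360 nM. The step of a 1.5-fold lower number from compound 1 to compound 2 (0.17 log units; within the scatter) is the only one measured so far and it falls within the scatter, so on the numbers shown compound 2 sits at the same level as compound 1 and is not separated from it.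

Compound 3 `CCN(CC)S(=O)(=O)c1ccc(S(=O)(=O)N2CCC[C@@H](C(=O)N3CCC(F)(F)CC3)C2)cc1` has not yet been measured. Relative to compound 2 the change is 4,4-difluoropiperidin-1-yl in place of 4-(methoxymethyl)piperidin-1-yl on a carbonyl carbon. Among the compounds with values here, the one measured step at this position, a 1.5-fold lower number from compound 1 to compound 2 (0.17 log units; within the scatter), is the only comparison available and shows no movement beyond the scatter. For compound 3 in this assay the expected step is therefore a 1.1-fold higher number from compound 2 to compound 3 (0.04 log units; within the scatter), none beyond the scatter. Compound 3 is estimated at 1500 nM, with a range from 600 nM to 4000 nM.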

Compound 3, half-maximal inhibitory concentration: 120 nM
Beside the measured number, compound 3's estimate is 13-fold (1.10 log units) above it, outside the stated range (below it).
By their numbers in this assay, from the lowest: compound 3; then compounds 2 and 1 (each within the scatter of the next).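

In this assay, within the data shown here, the group on the carbonyl carbon proves able to move the number: the new group gives an 11-fold lower number from compound 2 to compound 3 (1.05 log units; beyond the scatter) and a 17-fold lower number from compound 1 to compound 3 (1.22 log units; beyond the scatter) while the only earlier step stayed within the scatter. Compound 3 is thus the one compound shown that separates from the others, with 4,4-difluoropiperidin-1-yl keeping the six-membered ring of 4-(methoxymethyl)piperidin-1-yl but carrying no hydrogen-bond acceptor. Nothing available bears on why this change has so large a step.

The compounds shown do not tell whether the step comes from the fluorine atoms or from losing the methoxymethyl group. Plain piperidin-1-yl and 4,4-dimethylpiperidin-1-yl on the same carbonyl carbon would separate these two readings.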